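This account rests on a few compounds, and the source may have more. Where it says the series, first, only, none or still open, it means among the compounds named here.

Compound 2 `O=C1CCC(=O)N1C[C@H]1CN(c2ccc(-n3cc(-c4ccccn4)cn3)c(F)c2)C(=O)O1` sits at the lower end of the two values seen so far in a physicochemical assay for lipophilicity, read by HPLC, measured as octanol-water partition (on this read-out lower numbers stand for lower lipophilicity and higher numbers for higher lipophilicity), where compound 2 gives 1.58. Among the measured compounds shown here, the only neighbour is compound 1 `O=C1O[C@@H](CN2CCC(O)CC2)CN1c1ccc(-n2cc(-c3ccccn3)cn2)c(F)c1`, which in this assay gives 1.63; the step of a number 0.05 log units lower from compound 1 to compound 2 (within the scatter) exchanged one ring for another on the same chain carbon and left the number where it was.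

Compound 3 `O=C1CNC(=O)N1C[C@H]1CN(c2ccc(-n3cc(-c4ccccn4)cn3)c(F)c2)C(=O)O1` is not yet measured in this assay. It differs from compound 2 by 2,5-dioxoimidazolidin-1-yl in place of 2,5-dioxopyrrolidin-1-yl on a saturated chain carbon bound to a saturated ring carbon. For the measured compounds named here, no measured step covers this exchange: the one step seen, from compound 1 to compound 2, concerns a different pair of groups and therefore gives no direct size for it. With one ring carbon replaced by a ring nitrogen and one hydrogen-bond donor entering, a downward step in this assay is expected, of size a number 0.43 log units lower from compound 2 to compound 3 (beyond the scatter). Compound 3 is thus estimated at 1.15, within a range from 0.75 to 1.55.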

Compound 3, partition coefficient: 1.25
For compound 3 the middle estimate is 0.10 log units below the measured one; measured number inside the range.
By their numbers in this assay, from the lowest: compound 3; then compounds 2 and 1 (each within the scatter of the next).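

At the place on a saturated chain carbon bound to a saturated ring carbon, this assay does respond to the choice of ring: 2,5-dioxoimidazolidin-1-yl in place of 2,5-dioxopyrrolidin-1-yl gives a number 0.33 log units lower from compound 2 to compound 3 (beyond the scatter) as one hetero atom becomes 2 and 1 hydrogen-bond donor enters. The same group in place of 4-hydroxypiperidin-1-yl gives a number 0.38 log units lower from compound 1 to compound 3 (beyond the scatter) and so sets compound 3 apart from both earlier compounds, which lie within the scatter of each other. Nothing available bears on the cause of these steps.

Still open, as far as these compounds go, is whether a methyl group on the new ring nitrogen would bring the number back towards that of compound 2, and where an amine or a carboxylic acid on this chain carbon would fall. From the compounds shown here alone, all three compounds share one core, so the size of this step on any other core remains unknown.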